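This account rests on a few compounds, and the source may have more. Where it says the series, first, only, none or still open, it means among the compounds named here.

Measured so far in a functional assay on PC-3 cells (Homo sapiens) for antiproliferative activity, read by MTT assay, with a stated time of 48 h; a higher number here means a weaker inhibitor of growth, a lower number a stronger inhibitor of growth

- compound 1 `CCOc1cc(NC(=O)CCCCCC(=O)Nc2cc(-c3ccccc3)ccc2N)cc2c1OCC([N+](=O)[O-])=C2` gives 7080 nM
- compound 2 `CCOc1cc(NC(=O)CCCCCC(=O)Nc2cc(-c3ccc(C)s3)ccc2N)cc2c1OCC([N+](=O)[O-])=C2` gives 11400 nM

Among the compounds with values here, compound 2 stands within the scatter of compound 1, the only other measured compound. Compound 3 `CCOc1cc(NC(=O)CCCCCC(=O)Nc2ccccc2N)cc2c1OCC([N+](=O)[O-])=C2` has hydrogen in place of 5-methylthiophen-2-yl on an aromatic carbon. Within the data shown here, the one measured step, a 1.6-fold higher number from compound 1 to compound 2 (0.21 log units; within the scatter), bears on this only indirectly, as it swaps one ring for another and removes neither. No step beyond the scatter is therefore expected, though with wide uncertainty. The estimated step is a 1.4-fold lower number from compound 2 to compound 3 (0.15 log units; within the scatter). For compound 3 the expected value is 8000 nM, with an estimated range from 2500 nM to 25000 nM.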

Compound 3, concentration for 50% growth inhibition: > 20000 nM
Compound 3 gave a limit, no number; the forecaster's own chance of this, stated with the estimate: 10%; middle value at least 2.5-fold (0.39 log units) from the limit.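

In this assay, compound 3 gives a limit and not a number: the limit of > 20000 nM in this assay, at which 1 of the 3 values shown sits. The earlier pair only swapped one ring for another, whereas hydrogen in place of phenyl, on the carbon para to an amino group, gives an at least 2.8-fold higher number from compound 1 to compound 3 (0.45 log units; beyond the scatter), so phenyl here goes with stronger growth inhibition than hydrogen. Hydrogen in place of 5-methylthiophen-2-yl gives an at least 1.7-fold higher number from compound 2 to compound 3 (0.24 log units; that floor lies within the scatter), so that loss is not firmly shown for this ring.

From the compounds shown here alone, the true size of both steps stays open with only a limit in hand. Going by these compounds, it also stays open whether a smaller group at this position, such as methyl or an amine, would match the rings.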